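The source may hold more compounds than are shown below. What is called first, only, known or untested is meant among the compounds shown, and "the series" means these compounds.

Compound 1 `Cc1c(C(=O)O)ccn1-c1ccccc1` has a five-membered aromatic ring with one nitrogen, bearing a carboxy group and a methyl group, with a phenyl group on the ring nitrogen. In an assay on cells for inhibition of Palmitoleoyl-protein carboxylesterase NOTUM variant C330S (Homo sapiens), read by fluorescence, with a stated time of 40 min (a higher number here means a weaker inhibitor, a lower number a stronger inhibitor), compound 1 gives 3800 nM. Compound 2 `Cc1c(C(=O)O)cc(C(F)(F)F)n1-c1ccccc1` differs from compound 1 in a single place: trifluoromethyl in place of hydrogen on an aromatic carbon. In this assay compound 2 gives 22000 nM, so the step is a 5.8-fold higher number from compound 1 to compound 2 (0.76 log units; beyond the scatter).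

Compound 3 `Cc1c(C(=O)O)ccn1Cc1ccccc1` shares the carboxy and methyl pattern but has a different core; the difference between the two cores is not broken down here. In this assay compound 3 gives 3100 nM, a number that sits within the usual scatter of the number for compound 1, while compound 2 stands further off from both.

Compound 4 `Cc1c(C(=O)O)cc(C(F)(F)F)n1Cc1ccccc1`, not yet measured, relates to compound 3 as compound 2 relates to compound 1: trifluoromethyl in place of hydrogen on an aromatic carbon. The surroundings are not identical, however. In compound 1 the place is next to the ring atom that bears a phenyl group (6 heavy atoms), whereas in compound 3 it is next to the ring atom that bears a group of 7 heavy atoms, so this is the same kind of change rather than the same one.

For the measured compounds named here, the expectation for compound 4 is a step of about a 5.2-fold higher number from compound 3 to compound 4 (0.71 log units; beyond the scatter), resting on the one earlier example, the step of a 5.8-fold higher number from compound 1 to compound 2 (0.76 log units; beyond the scatter). Compound 4 is therefore estimated at 16000 nM in this assay, most likely between 6000 nM and 45000 nM.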

Compound 4, half-maximal inhibitory concentration: > 100000 nM
Compound 4 ended at the assay's limit (the forecaster's own chance of this, stated with the estimate: 10%); middle value at least 6.2-fold (0.79 log units) away from the limit.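

Compound 4 gives > 100000 nM in this assay, which is a limit of the assay and not a number. Putting trifluoromethyl in place of hydrogen on an aromatic carbon gives an at least 32-fold higher number from compound 3 to compound 4 (1.50 log units; beyond the scatter), so the change moves the number in the same direction on both cores, but its size does not carry over from one to the other: the same change on two cores in this assay, a 5.8-fold higher number (0.76 log units; beyond the scatter) from compound 1 to compound 2 and an at least 32-fold higher number (1.50 log units; beyond the scatter) from compound 3 to compound 4, at least 5.5-fold (0.74 log units) apart, beyond the scatter of two such steps What this shows is that, in these two pairs, the direction held while a step read on the core of compound 1 did not predict the size of the step on the core of compound 3; it does not show how large the second step really is, as the limit gives it no upper end, and two pairs alone cannot tell which difference between the cores goes with the gap.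

From the compounds shown here alone, whether a nitrile or a chlorine atom in place of that same hydrogen would also differ so much from one core to the other stays open. So does the question of how a longer chain in place of the group of 7 heavy atoms would respond to trifluoromethyl at that place.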